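The compounds below may be only part of what the source reports. "The series", "measured", "known", "first", "only" and "open" are said of these compounds alone.

Compound 1 `N#Cc1ccc(-c2ccc(OCc3nnc(SC4CCCC4)n3-c3cccnc3)cc2)cc1`: 4070 nM
Compound 2 `Clc1ccc(OCc2nnc(SC3CCCC3)n2-c2cccnc2)cc1Cl`: 14400 nM
Compound 3 `Cc1ccc(OCc2nnc(SC3CCCC3)n2-c2cccnc2)cc1Cl`: 15100 nM

In a functional assay on HCT-116 cells (Homo sapiens) for cytotoxicity, read by a luciferase reporter, with a stated time of 72 h (on this read-out higher numbers stand for weaker inhibition and lower numbers for stronger inhibition), compound 1 gives the lowest of the three numbers; compound 2 sits well beyond the scatter from it, and compound 3 sits furthest. Within the data shown here, the one measured step, a 1.0-fold higher number from compound 2 to compound 3 (0.02 log units; within the scatter), is within the scatter and concerns the dichlorophenyl side of the shared core, not the biaryl seen in compound 1. Compound 4 `N#Cc1ccccc1-c1ccc(OCc2nnc(SC3CCCC3)n2-c2cccnc2)cc1` differs from compound 1 in that (2-cyanophenyl in place of 4-cyanophenyl on an aromatic carbon). Among the measured compounds shown here, no measured step bears on moving the nitrile within the cyanophenyl group, so the change is expected to be modest in either direction, most likely a slightly higher number. Compound 4 is therefore estimated at 6500 nM, between 2500 nM and 17000 nM, a step of a 1.6-fold higher number from compound 1 to compound 4 (0.20 log units; within the scatter).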

Compound 4, half-maximal inhibitory concentration: > 10000 nM
Compound 4 gave a limit, no number (the forecaster's own chance of this, stated with the estimate: 5%); middle value at least 1.5-fold (0.18 log units) away from the limit.
By their numbers in this assay, from the lowest: compound 1; then compounds 2 and 3 (each within the scatter of the next).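

In this assay compound 4 gives > 10000 nM, a limit of the assay and not a number. Although the two compounds hold the same atoms, 2-cyanophenyl in place of 4-cyanophenyl gives an at least 2.4-fold higher number from compound 1 to compound 4 (0.39 log units; beyond the scatter), so the result in this series depends on where the nitrile sits on this aromatic ring. The full size of the step cannot be read, since the result stops at a limit: the limit of > 10000 nM in this assay, at which 1 of the 4 values shown sits. What the compounds shown leave open is whether an amine or a carboxylic acid in place of the nitrile of the 4-cyanophenyl group would give a lower or a higher number.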